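Dimethylsulfamoyl for dimethylamino on the aryl ring

The source may report more compounds than this note shows. Statements on the series, on what has been measured and on what is new or still open speak of the compounds shown alone.

Measured compounds:
compound 1, `CCOc1ccc(S(=O)(=O)N(C)C)cc1-c1ncc(C(=O)O)c(=O)[nH]1`: > 50 mg/kg
compound 2, `CCOC(=O)c1cnc(-c2cc(N(C)C)ccc2OCC)[nH]c1=O`: "not determined" (no result reported)

Compound 1 was tested in a functional assay on the whole organism (strain Sprague-Dawley) for inhibition, with Rattus norvegicus as the target, with a stated time of 10 min (a higher number here means that more compound is needed for the effect, a lower number that less compound is needed), and reached only a limit of the assay, > 50 mg/kg. This is the line the limit of > 50 mg/kg in this assay, at which 1 of the 2 values shown sits, at which one of the two values shown sits. Going by the values given here, compound 2 has no single number in this assay; its result is given as "not determined" (no result reported), so no measured step between compound 1 and compound 2 can be stated, and compound 2 cannot be placed on the scale.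

Compound 3, `CCOC(=O)c1cnc(-c2cc(S(=O)(=O)N(C)C)ccc2OCC)[nH]c1=O`, has not yet been measured in this assay. It differs from compound 2 by dimethylsulfamoyl in place of dimethylamino on an aromatic carbon. With no starting number for compound 2, no direction for this step can be read from the data, and a step no larger than the scatter is as likely as any other. Compound 3 is expected to give roughly 40 mg/kg in this assay, within 10 mg/kg to 100 mg/kg.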

Compound 3, dose for 50% inhibition: 50 mg/kg
The estimate for compound 3 lay 1.3-fold (0.10 log units) below the measured number; the measured number falls inside the stated range.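

In this assay compound 3 gives a plain number, 50 mg/kg, so dimethylsulfamoyl para to an ethoxy group now has a value that is not a limit. Compound 1, which carries the same dimethylsulfamoyl group but has hydrogen in place of ethyl on an oxygen next to a carbonyl group, reached only a limit of the assay: the limit of > 50 mg/kg in this assay, at which 1 of the 3 values shown sits. The step with ethyl in place of hydrogen on an oxygen next to a carbonyl group is a number no higher from compound 1 to compound 3 (the limit leaves the size open) and its size cannot be read, and compound 2 has no number to set against compound 3, so the change from dimethylamino to dimethylsulfamoyl has no measured size.

Going by these compounds, it remains open how a primary amine, a nitrile or a sulfonamide with longer chains on its nitrogen would compare on this aromatic carbon in this assay. The ethyl ester is likewise untested against a longer ester chain.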